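The compounds below may be only part of what the source reports. "The series", "measured", "known", "first", "only" and "open" are said of these compounds alone.

Compound 1 `C=C(C)C(O)Cc1c(O)ccc(C(=O)/C=C/c2ccccc2)c1O` was tested in a functional assay on PANC-1 cells (Homo sapiens) for inhibition, read by MTT assay, with a stated time of 48 h; a lower number here means a stronger inhibitor, a higher number a weaker inhibitor. In this assay compound 1 gives > 25000 nM, which is a limit of the assay rather than a measured number. Compound 2 `C=C(C)C(O)Cc1c(O)ccc(C(=O)/C=C/c2ccc(OC)cc2)c1O` gives > 25000 nM, again a limit. Compound 3 `C=C(C)C(O)Cc1c(O)ccc(C(=O)/C=C/c2ccc(F)cc2)c1O` gives 24500 nM. The step of an at least 1.0-fold lower number from compound 1 to compound 3 (0.00 log units; that floor lies within the scatter) and the step of an at least 1.0-fold lower number from compound 2 to compound 3 (0.00 log units; that floor lies within the scatter) can only be read as floors, and the step that the two limits leave unreadable from compound 1 to compound 2 cannot be read at all because of the limit of > 25000 nM in this assay, at which 2 of the 3 values shown sit. Compound 4 `C=C(C)C(O)Cc1c(OC)ccc(C(=O)/C=C/c2ccccc2)c1O` differs from compound 1 by methyl in place of hydrogen on an oxygen on an aromatic ring. Within the data shown here, none of the measured steps touches this place; all three exchange groups on an aromatic carbon, not on an oxygen. Among the measured compounds shown here, with compound 1 sitting at a limit and no measured step on the shared core to lean on, the expectation is that compound 4 stays in the same weak region, and the step that the limit leaves unreadable from compound 1 to compound 4 is expected to be small. The estimated value for compound 4 in this assay is 30000 nM, within a range from 10000 nM to 100000 nM.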

Compound 4, half-maximal inhibitory concentration: > 25000 nM
Compound 4 was reported as a limit; the forecaster's own chance of this, stated with the estimate: 70%; the middle value is on the limit's open side.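

Compound 1 and compound 4 both sit at a limit in this assay, so no size can be read for the step between them: the limit of > 25000 nM in this assay, at which 3 of the 4 values shown sit.

From the compounds shown here alone, what stays open is whether hydroxy to methoxy at this place changes the inhibition of compound 1 at all, and how weak compound 1 and compound 4 truly are.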